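Methoxy in place of fluoro: a small expected step

A few compounds are considered here, and "the series" means these few. Any claim that something is new, unique, unknown or untested is made for them only; others in the source may bear on it.

In a functional assay on NCI-H460 cells (Homo sapiens) for inhibition, read by MTT assay, with a stated time of 24 h, tested at 100 ug/mL (on this read-out lower numbers stand for less inhibition of growth and higher numbers for more inhibition of growth at the one concentration tested), compound 1 (`O=C(O)CCCCC(CCSC(=O)c1ccccc1)SC(=O)c1ccccc1`) gives 72.8% inhibition, compound 2 (`O=C(CCCCC(S)CCS)NO`) gives 43.7% inhibition and compound 3 (`O=C(CCCCC(S)CCS)Nc1ccc(F)cc1`) gives 41.6% inhibition. Compound 3 therefore sits level with compound 2 within the usual scatter, while the gap up to compound 1 lies beyond it. Compound 4 (`COc1ccc(NC(=O)CCCCC(S)CCS)cc1`) has methoxy in place of fluoro on an aromatic carbon. Among the compounds with values here, no measured pair shows this change alone. Within the data shown here, the only guide is that compound 2 at 43.7% and compound 3 at 41.6% lie within the scatter despite their different end groups, so no step beyond the scatter is expected. The expected change is a number 1.4 percentage points higher from compound 3 to compound 4 (within the scatter) and stays within that scatter. The estimate for compound 4 is 43% inhibition, in an expected range of 32% to 54% inhibition.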

Compound 4, percent growth inhibition at one concentration: 23.5%
For compound 4 the middle estimate is 19.5 percentage points above the measured one, outside the stated range (below it).
By their numbers in this assay, from the lowest: compound 4; then compounds 3 and 2 (each within the scatter of the next); then compound 1.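

Within the data shown here, the earlier compounds offered no pair differing in one place, and this is the first direct reading of a single change. In this assay methoxy in place of fluoro, on an aromatic carbon para to a large group, gives a number 18.1 percentage points lower from compound 3 to compound 4 (beyond the scatter) and so shows that the group at this position can matter. Nothing available explains this step. The compounds shown leave open how a chloro, a hydroxyl or an amine at this position would compare. They also leave open whether the same change would give a similar step with a different end group.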